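A few compounds are considered here, and "the series" means these few. Any claim that something is new, unique, unknown or untested is made for them only; others in the source may bear on it.

Of the compounds shown here, two of this family have been tested in a functional assay on OVCAR-3 cells (Homo sapiens) for inhibition (on this read-out higher numbers stand for weaker inhibition of growth and lower numbers for stronger inhibition of growth), and neither gives a number. Compound 1, `C=C1CCCC(C)(C)C1CC[C@]1(C)CC[C@@H]([C@@H](C)C(=O)O)OO1`, comes out in this assay at > 10000 nM, which is a limit of the assay. Compound 2, `CC1=C(CC/C(C)=C/CC[C@@]2(C)CC[C@@H]([C@H](C)C(=O)O)OO2)C(C)(C)CCC1`, comes out in this assay at > 100000 nM, also a limit and not a number. Within the data shown here, compound 2 therefore stands at a limit, and the one other value shown is a limit as well, so the two cannot be placed in any order (the limit of > 10000 nM in this assay, at which 1 of the 2 values shown sits, (the limit of > 100000 nM in this assay, at which 1 of the 2 values shown sits)).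

Compound 3, `CC1=C(CC/C(C)=C/CC[C@@]2(C)CC[C@H]([C@H](C)C(=O)O)OO2)C(C)(C)CCC1`, is still to be measured. It keeps every atom and bond of compound 2 and differs only in configuration at one stereocentre at a saturated ring carbon: the two compounds have the same atoms and bonds and differ only in configuration as drawn: 1 of 4 stereo elements differ; a stereocentre at a saturated ring carbon is drawn S in compound 2 and R in compound 3.

Among the measured compounds shown here, no step between measured compounds exists here, so no measured size of change can guide the expectation. The change from compound 2 to compound 3 is expected to give no step beyond the scatter, roughly a number no higher from compound 2 to compound 3 (the limit leaves the size open). Compound 3 is thus expected to sit at about 100000 nM, with a range from 20000 nM to 400000 nM, most likely again reported only as a limit.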

Compound 3, concentration for 50% growth inhibition: > 5000 nM
Compound 3 ended at the assay's limit (the forecaster's own chance of this, stated with the estimate: 80%); the middle value is on the limit's open side.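

In this assay, compound 2 and compound 3 both end at limits of the assay rather than at numbers, so no step can be read between them. The compounds shown leave open whether changing the configuration at this one stereocentre alters growth inhibition at all, and how strongly any of the three compounds inhibits growth.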